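Swapping Cyclohexyl for Pyridin-2-yl at the Amide Tail

The source may hold more compounds than are shown below. What is called first, only, known or untested is meant among the compounds shown, and "the series" means these compounds.

compound 1 `COc1cccc(OC)c1C(=O)Nc1c[nH]nc1C(=O)NC1CC1`: > 50000 nM
compound 2 `COc1cccc(OC)c1C(=O)Nc1c[nH]nc1C(=O)NCc1ccccc1`: 50000 nM
compound 3 `COc1cccc(OC)c1C(=O)Nc1c[nH]nc1C(=O)NCC1CCCCC1`: > 50000 nM

Three compounds share one core and differ only in the group on the amide nitrogen. In an ADME assay on MRC5 cells (Homo sapiens) for inhibition, with a stated time of 72 h (a lower number here means that less compound is needed, a higher number that more compound is needed for the effect), compound 3 reports only a limit of the assay, > 50000 nM, not a number. Compound 1 likewise sits at a limit, > 50000 nM. Compound 2 gives 50000 nM. Neither a step that the two limits leave unreadable from compound 1 to compound 3 nor a number no lower from compound 2 to compound 3 (the limit leaves the size open) can be sized, because of the limit of > 50000 nM in this assay, at which 2 of the 3 values shown sit.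

Compound 4 `COc1cccc(OC)c1C(=O)Nc1c[nH]nc1C(=O)NCc1ccccn1` carries pyridin-2-yl in place of cyclohexyl on a saturated chain carbon bound to an amide-type nitrogen. The nearest measured step, a number no lower from compound 2 to compound 3 (the limit leaves the size open), also exchanges the ring on that carbon, yet gives no readable size, so no shift beyond the scatter is expected; the step of a number no higher from compound 3 to compound 4 (the limit leaves the size open) is an estimate. Compound 4 is expected to give 50000 nM, within 20000 nM to 100000 nM.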

Compound 4, half-maximal effective concentration: > 50000 nM
Compound 4 gave a limit, no number (the forecaster's own chance of this, stated with the estimate: 60%); the middle value lies on the limit itself.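

Exchanging cyclohexyl for pyridin-2-yl, which brings a ring nitrogen and a hydrogen-bond acceptor to this saturated chain carbon, does not yield a readable number in this assay. Compound 2, with phenyl on that carbon, remains the only one of the four to give a number, 50000 nM, and pyridin-2-yl in place of phenyl gives a number no lower from compound 2 to compound 4 (the limit leaves the size open). None of the steps to compound 4 can be read, because the values sit at the limit: the limit of > 50000 nM in this assay, at which 3 of the 4 values shown sit.

Going by these compounds, how far the values of compound 1, compound 3 and compound 4 lie from one another stays open. So does whether a longer chain or a carboxylic acid on the amide nitrogen would give a number.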